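Flipping two ring centres in a small sugar-like acid

The compounds below may be only part of what the source reports. "The series", "measured", "known", "first", "only" and "open" are said of these compounds alone.

Of the compounds shown here, three built on one shared core have been tested in an assay on isolated protein for inhibition of cytosolic endo-beta-N-acetylglucosaminidase (Homo sapiens), tested at 1000 uM (on this read-out lower numbers stand for less inhibition and higher numbers for more inhibition at the one concentration tested (going by the name of the read-out)), all at the same concentration. Compound 1, `O=C(O)[C@H]1NC[C@@H](O)[C@H](O)[C@H]1O`, gives 6.3%. Compound 2, `O=C(O)[C@H]1NC[C@@H](O)[C@@H](O)[C@@H]1O`, gives 28%. Compound 3, `O=C(O)[C@H]1NC[C@H](O)[C@@H](O)[C@H]1O`, gives 2.6%, the lowest of the three numbers, though its gap to compound 1 lies within the scatter and only its gap to compound 2 is beyond it.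

Every measured step here is a change of configuration alone. The step of a number 21.7 percentage points higher from compound 1 to compound 2 (beyond the scatter) and the step of a number 25.4 percentage points lower from compound 2 to compound 3 (beyond the scatter) are both modest, while the step of a number 3.7 percentage points lower from compound 1 to compound 3 (within the scatter) lies within the scatter, so two such flips may change this read-out by a modest amount or not at all.

Compound 4, `O=C(O)[C@@H]1NC[C@H](O)[C@@H](O)[C@@H]1O`, differs from compound 3 in the same manner: the two compounds have the same atoms and bonds and differ only in configuration as drawn: 2 of 4 stereo elements differ; a stereocentre at a saturated ring carbon is drawn S in compound 3 and R in compound 4; a stereocentre at a saturated ring carbon is drawn S in compound 3 and R in compound 4. The steps seen so far suggest that the step of a number 7.4 percentage points higher from compound 3 to compound 4 (within the scatter) is expected to be small, most likely upward or within the scatter, since compound 3 starts near the bottom of the range seen. Compound 4 is therefore estimated to give 10% in this assay, within a range from 0% to 30%.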

Compound 4, a percentage reported as inhibition, at one concentration (the size of the read-out at that concentration, not a potency): 5.4%
The estimate for compound 4 lay 4.6 percentage points above the measured number; low and high end bracket the measured number.
By their numbers in this assay, from the lowest: compounds 3, 4 and 1 (each within the scatter of the next); then compound 2.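

The new compound shows that a second, different pair of flipped centres can also leave this assay unmoved, giving a number 2.8 percentage points higher from compound 3 to compound 4 (within the scatter). It also adds the first full mirror-image comparison, where inverting all four stereocentres gives a number 0.9 percentage points lower from compound 1 to compound 4 (within the scatter), so in this pair the complete inversion of the shared core produces no readable change: the fact that compounds 1 and 4 differ only in the configuration as drawn Compound 2 stays apart, with a number 22.6 percentage points lower from compound 2 to compound 4 (beyond the scatter), so compound 4 joins compound 1 and compound 3 as a third compound whose number lies beyond the scatter from that of compound 2, and the arrangement of centres in compound 2 is the only one shown here that stands out.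

All of these numbers come from one high concentration and give no potency, so they cannot show how much the stereocentres matter at lower concentrations, and the small differences among compound 1, compound 3 and compound 4 cannot be read. On these data alone, it also remains open whether the higher number of compound 2 would persist with a methyl ester or a primary amide in place of the carboxylic acid, or with a longer chain on the nitrogen.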